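Removing the benzyl group from compound 3

The source may hold more compounds than are shown below. What is called first, only, known or untested is meant among the compounds shown, and "the series" means these compounds.

Compound 3 (`COc1ccc(-c2cc(C(=O)O)sc2-c2cc(OC)c(OC)c(OC)c2)cc1OCc1ccccc1`) reads > 100000 nM in a functional assay on KB cells (Homo sapiens) for antiproliferative activity, read by MTT assay, with a stated time of 72 h (a lower number here means a stronger inhibitor, a higher number a weaker inhibitor), which is a limit and not a number. Compound 1 (`CCOC(=O)c1cc(-c2ccc(OC)c(O)c2)c(-c2cc(OC)c(OC)c(OC)c2)s1`) reads > 100000 nM in this assay, also a limit. Compound 3 and compound 1 therefore both stand at the limit of > 100000 nM in this assay, at which 2 of the 3 values shown sit, and compound 3 has no measured position in the series. Compound 2 (`COc1ccc(-c2cc(C(=O)O)sc2-c2cc(OC)c(OC)c(OC)c2)cc1`) gives 8650 nM in this assay as a measured value.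

Compound 4 (`COc1ccc(-c2cc(C(=O)O)sc2-c2cc(OC)c(OC)c(OC)c2)cc1O`) carries hydrogen in place of benzyl on an oxygen on an aromatic ring, (hydrogen in place of benzyl on an oxygen on an aromatic ring), so benzyloxy becomes hydroxy. For the measured compounds named here, the one measured step bearing on this change is an at least 11-fold higher number from compound 2 to compound 3 (1.06 log units; beyond the scatter), with benzyloxy in place of hydrogen on an aromatic carbon. It was large, so a large step to a lower number is expected in this assay on removing the benzyl group. The expected size is an at least 10-fold lower number from compound 3 to compound 4 (1.00 log units; beyond the scatter) by estimate. Compound 4 is expected at an estimated 10000 nM, within a range of 1500 nM to 60000 nM as the likely span.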

Compound 4, half-maximal inhibitory concentration: 21800 nM
Estimate against measurement, compound 4: 2.2-fold (0.34 log units) below; the range from low to high includes it.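

Hydroxy in place of benzyloxy on this oxygen brings the series back to a measured value in this assay (an at least 4.5-fold lower number from compound 3 to compound 4 (0.66 log units; beyond the scatter)), so the benzyl group costs more than the oxygen itself, though this step is only a bound, as compound 3 reads at a limit: the limit of > 100000 nM in this assay, at which 2 of the 4 values shown sit. The oxygen is still not neutral, since hydroxy in place of hydrogen gives a higher number (a 2.5-fold higher number from compound 2 to compound 4 (0.40 log units; beyond the scatter)), leaving hydrogen best of the three at this place. With the hydroxy fixed, the first pair changing the other end of the core shows that hydrogen in place of ethyl on an oxygen next to a carbonyl group gives a lower number (an at least 4.5-fold lower number from compound 1 to compound 4 (0.66 log units; beyond the scatter)), again only a bound.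

From the compounds shown here alone, whether a methyl or a longer chain on this oxygen falls nearer hydroxy or benzyloxy stays open. So does whether an amine at this place would match hydrogen.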